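This account rests on a few compounds, and the source may have more. Where it says the series, first, only, none or still open, it means among the compounds named here.

Among the measured compounds shown here, in a functional assay on KB cells (Homo sapiens) for cytotoxicity (on this read-out lower numbers stand for stronger inhibition and higher numbers for weaker inhibition), three compounds with a shared core have numbers so far: compound 1 `COc1ccc(S(=O)(=O)N2CCc3cccc(NC(=O)c4ccc([N+](=O)[O-])cc4)c32)cc1` gives 102 nM and compound 2 `COc1ccc(S(=O)(=O)N2CCc3cccc(NC(=O)c4ccncc4)c32)cc1` gives 9.6 nM while compound 3 `COc1ccc(S(=O)(=O)N2CCc3cccc(NS(=O)(=O)c4ccccc4)c32)cc1` gives 650 nM as the highest of the three. Compound 4 `COc1ccc(S(=O)(=O)N2CCc3cccc(NC(=O)c4ccco4)c32)cc1` differs from compound 3 as follows: (furan-2-yl)carbonyl in place of phenylsulfonyl on a nitrogen on an aromatic ring so (furan-2-yl)carbonyl stands in place of phenylsulfonyl on a nitrogen on an aromatic ring. The closest parallel is the large step of a 68-fold higher number from compound 2 to compound 3 (1.83 log units; beyond the scatter) which ran the other way, with phenylsulfonyl entering in place of (pyridin-4-yl)carbonyl. The large step of an 11-fold lower number from compound 1 to compound 2 (1.03 log units; beyond the scatter) shows that the ring on the carbonyl carbon also moves the number, so the size stays uncertain. A large drop is expected in this assay and the estimated step is a 22-fold lower number from compound 3 to compound 4 (1.34 log units; beyond the scatter) beyond the scatter. Compound 4 is estimated at 30 nM with an expected range from 8 nM to 120 nM in this read-out.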

Compound 4, half-maximal inhibitory concentration: 9.6 nM
Estimate against measurement, compound 4: 3.1-fold (0.49 log units) above, within the range that was stated.
By their numbers in this assay, from the lowest: compounds 2 and 4 (each within the scatter of the next); then compound 1; then compound 3.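

In this assay, the swap at this nitrogen gives a 68-fold lower number from compound 3 to compound 4 (1.83 log units; beyond the scatter) and brings a second ring on a carbonyl carbon to the low end of the series. Changing that ring gives no change at the digits printed from compound 2 to compound 4 (within the scatter), so furan-2-yl and pyridin-4-yl cannot be told apart here, whereas the other comparison gives an 11-fold lower number from compound 1 to compound 4 (1.03 log units; beyond the scatter) and shows that 4-nitrophenyl does not behave like either. Nothing available explains these steps. As far as these compounds go, because the sulfonyl link and the ring changed together from compound 3 to compound 4, their separate shares remain unknown. A benzoyl group or a furan-2-ylsulfonyl group at this nitrogen would separate them.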